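Removing a Protected Amine Chain for a Piperazine Amide

The source may hold more compounds than are shown below. What is called first, only, known or untested is meant among the compounds shown, and "the series" means these compounds.

Compound 1 `CC(C)(C)OC(=O)NCCCNC(=O)CN1CN(c2ccccc2)C2(CCN(C(=O)c3ccc(C(C)(C)C)cc3)CC2)C1=O` gives 4500 nM in an assay on HEK293 cells for displacement of a labelled ligand from NPC1-like intracellular cholesterol transporter 1 (Homo sapiens) (on this read-out higher numbers stand for weaker inhibition and lower numbers for stronger inhibition), the second highest of three numbers: it sits within the scatter of compound 3 `CC(C)(C)OC(=O)NC1CCN(C(=O)CN2CN(c3ccccc3)C3(CCN(C(=O)c4ccc(C5CCCCC5)cc4)CC3)C2=O)CC1`, at 4800 nM, and well above compound 2 `O=C(CN1CN(c2ccccc2)C2(CCN(C(=O)c3ccc(C4CCCCC4)cc3)CC2)C1=O)N1CCCCC1`, at 1100 nM. Compound 4 `CC(C)(C)c1ccc(C(=O)N2CCC3(CC2)C(=O)N(CC(=O)N2CCNCC2)CN3c2ccccc2)cc1` differs from compound 1 by piperazin-1-yl in place of (3-((tert-butoxycarbonyl)amino)propyl)amino on a carbonyl carbon. The only single-point step shown, a 4.4-fold higher number from compound 2 to compound 3 (0.64 log units; beyond the scatter), concerns the same (tert-butoxycarbonyl)amino group that here leaves. Since that step weakened binding, its removal in compound 4 is expected to run the other way, a modest step toward a lower number, though compound 2 and compound 3 carry a different aryl group than compound 1. Compound 4 is therefore estimated at 1500 nM, between 500 nM and 5000 nM, a step of a 3.0-fold lower number from compound 1 to compound 4 (0.48 log units; beyond the scatter).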

Compound 4, half-maximal inhibitory concentration: 22000 nM
The estimate for compound 4 lay 15-fold (1.17 log units) below the measured number; measured number above the stated range.
By their numbers in this assay, from the lowest: compound 2; then compounds 1 and 3 (each within the scatter of the next); then compound 4.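

On a carbonyl carbon, piperazin-1-yl in place of (3-((tert-butoxycarbonyl)amino)propyl)amino gives a 4.9-fold higher number from compound 1 to compound 4 (0.69 log units; beyond the scatter) in this assay, so this exchange raises the number here. The (tert-butoxycarbonyl)amino group also raised it in a 4.4-fold higher number from compound 2 to compound 3 (0.64 log units; beyond the scatter), so its presence alone does not set the direction of change across these compounds. Nothing given here accounts for the rise in compound 4.

The compounds shown leave open whether the piperazine ring or the loss of the chain matters more. A free primary amine on the propyl chain, or an acetyl group on the piperazine nitrogen, would help separate the two.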